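The source may hold more compounds than are shown below. What is called first, only, known or untested is meant among the compounds shown, and "the series" means these compounds.

Going by the values given here, compound 3 `CCN1CCN(Cc2c(OC)cc(Oc3cccc(Nc4ccccc4)c3)cc2OC)CC1` is the one compound of the three measured that reaches the cut-off of a functional assay on DLD-1 cells (Homo sapiens) for inhibition, read by MTT assay, with a stated time of 72 h; on this read-out higher numbers stand for weaker inhibition and lower numbers for stronger inhibition: compound 3 gives > 20000 nM, which is a limit of this assay and not a number. Compound 1 `COc1cc(Oc2cccc(Nc3ccccc3)c2)cc(OC)c1CNCc1ccc(C)cc1` gives 6080 nM in this assay, and compound 2 `COc1cc(Oc2cccc(Nc3ccccc3)c2)cc(OC)c1CN[C@H](C)c1ccccc1` gives 8570 nM. Replacing either benzylic amine by the cyclic amine raised the number beyond the scatter: an at least 3.2-fold higher number from compound 1 to compound 3 (0.51 log units; beyond the scatter) and an at least 2.3-fold higher number from compound 2 to compound 3 (0.36 log units; beyond the scatter), whereas a 1.4-fold higher number from compound 1 to compound 2 (0.15 log units; within the scatter).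

Compound 4 `COc1cc(Oc2cccc(Nc3ccccc3)c2)cc(OC)c1CNCc1ccc(Br)cc1` differs from compound 3 by (4-bromobenzyl)amino in place of 4-ethylpiperazin-1-yl on a saturated chain carbon bound to an aromatic carbon. This is close to a reversal of the step from compound 1 to compound 3, with a 4-bromobenzyl group in place of the 4-methylbenzyl group. Since both steps toward the 4-ethylpiperazin-1-yl group gave higher numbers beyond the scatter, a lower number for compound 4 in this assay is expected, near where compound 1 stands. Compound 4 is therefore estimated at 6500 nM, expected between 3000 nM and 14000 nM. The expected step is an at least 3.0-fold lower number from compound 3 to compound 4 (0.48 log units; beyond the scatter).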

Compound 4, half-maximal inhibitory concentration: 3520 nM
Compound 4: the middle estimate sits 1.8-fold (0.27 log units) above what was measured; low and high end bracket the measured number.
By their numbers in this assay, from the lowest: compounds 4, 1 and 2 (each within the scatter of the next, the first and the last beyond it). At a limit, above all of these: compound 3.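

Compound 3 stands at a limit of this assay, which is not a number: the limit of > 20000 nM in this assay, at which 1 of the 4 values shown sits.
With (4-bromobenzyl)amino on a saturated chain carbon bound to an aromatic carbon, the higher number seen with 4-ethylpiperazin-1-yl does not persist (an at least 5.6-fold lower number from compound 3 to compound 4 (0.75 log units; beyond the scatter)), so this result extends the contrast with the ring to a second substituted benzyl group. On the amine nitrogen, 4-bromobenzyl in place of 1-phenylethyl gives a step beyond the scatter (a 2.4-fold lower number from compound 2 to compound 4 (0.39 log units; beyond the scatter)), whereas bromo in place of methyl on an aromatic carbon stays within it (a 1.7-fold lower number from compound 1 to compound 4 (0.24 log units; within the scatter)), leaving compound 1 and compound 4 without an order.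

Going by these compounds, whether a chloro, methoxy or unsubstituted benzyl group would stand with compound 1 and compound 4 remains open. Also open, on these data alone, is whether a morpholine or piperidine ring at this place would behave like 4-ethylpiperazin-1-yl.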